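A Dichlorophenyl for a Fluorophenyl on the Carbonyl

The source may hold more compounds than are shown below. What is called first, only, known or untested is meant among the compounds shown, and "the series" means these compounds.

Compound 1 `CN(C(=O)NC(=O)c1ccccc1F)c1nc(C(F)(F)F)c(C(=O)N/N=C/c2ccccc2C(F)(F)F)s1` is the reference. In a functional assay on BCG823 cells (Homo sapiens) for inhibition, read by MTT assay, with a stated time of 72 h (a higher number here means a weaker inhibitor, a lower number a stronger inhibitor), compound 1 gives 4.67 ug/mL, the lowest of the two numbers shown; the nearest is compound 3 `CN(C(=O)NC(=O)c1ccccc1F)c1nc(C(F)(F)F)c(C(=O)N/N=C/c2cccc(C(F)(F)F)c2)s1`, which gives 16.3 ug/mL. Compound 2 `CNc1nc(C(F)(F)F)c(C(=O)N/N=C/c2ccccc2C(F)(F)F)s1` reports only a limit, > 100 ug/mL. Compound 4 `CN(C(=O)NC(=O)c1c(Cl)cccc1Cl)c1nc(C(F)(F)F)c(C(=O)N/N=C/c2ccccc2C(F)(F)F)s1` is not yet measured; it differs from compound 1 in this way: 2,6-dichlorophenyl in place of 2-fluorophenyl on a carbonyl carbon. Of the measured steps, an at least 21-fold higher number from compound 1 to compound 2 (1.33 log units; beyond the scatter) shows that the whole ((2-fluorophenyl)carbonyl)carbamoyl group matters greatly, while a 3.5-fold higher number from compound 1 to compound 3 (0.54 log units; beyond the scatter) concerns a different part of the molecule. Neither step alters the ring on the carbonyl carbon, so only a small change is expected: a 1.1-fold higher number from compound 1 to compound 4 (0.03 log units; within the scatter). Compound 4 is therefore estimated at 5 ug/mL, with a range from 1.8 ug/mL to 15 ug/mL.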

Compound 4, half-maximal inhibitory concentration: 4.12 ug/mL
Compound 4: middle estimate off by 1.2-fold (0.08 log units), on the high side, within the range that was stated.
By their numbers in this assay, from the lowest: compounds 4 and 1 (each within the scatter of the next); then compound 3. At a limit, above all of these: compound 2.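

In this assay, among the compounds shown here, the ring on the carbonyl carbon changes for the first time, and 2,6-dichlorophenyl in place of 2-fluorophenyl gives a 1.1-fold lower number from compound 1 to compound 4 (0.05 log units; within the scatter). This position therefore accepts two chlorines instead of one fluorine with no change beyond the scatter, even though removing the whole ((2-fluorophenyl)carbonyl)carbamoyl group matters greatly. Nothing measured here explains why this swap makes so little difference. Only these two rings are shown at this position, so a plain phenyl, a cyclohexyl or a ring carrying an amine remains open. As far as these compounds go, whether 2,6-dichlorophenyl behaves the same alongside the 3-(trifluoromethyl)phenyl of compound 3 is also open.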